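Cyclopropyl to Hydrogen on the Triazolyl Carbon of Compound 3

The source may report more compounds than this note shows. Statements on the series, on what has been measured and on what is new or still open speak of the compounds shown alone.

Compound 1 `O=C1O[C@H]([C@@H](O)Cn2cc(-c3cccc(O)c3)nn2)C(OCc2ccccc2)=C1OCc1ccccc1` — 42900 nM
Compound 2 `O=C1O[C@H]([C@@H](O)Cn2cc(CCO)nn2)C(OCc2ccccc2)=C1OCc1ccccc1` — 72700 nM
Compound 3 `O=C1O[C@H]([C@@H](O)Cn2cc(C3CC3)nn2)C(OCc2ccccc2)=C1OCc1ccccc1` — 30400 nM

In a functional assay on HCT-116 cells (Homo sapiens) for antiproliferative activity, read by MTT assay, with a stated time of 72 h (on this read-out higher numbers stand for weaker inhibition and lower numbers for stronger inhibition), compound 3 gives the lowest of the three numbers; compound 1 stays within the scatter of it (a 1.4-fold lower number from compound 1 to compound 3 (0.15 log units; within the scatter)), while compound 2 lies beyond it (a 2.4-fold lower number from compound 2 to compound 3 (0.38 log units; beyond the scatter)). Compound 4 `O=C1O[C@H]([C@@H](O)Cn2ccnn2)C(OCc2ccccc2)=C1OCc1ccccc1` differs from compound 3 as follows: hydrogen in place of cyclopropyl on an aromatic carbon. Within the data shown here, the steps that bear on this change are a 1.4-fold lower number from compound 1 to compound 3 (0.15 log units; within the scatter) and a 2.4-fold lower number from compound 2 to compound 3 (0.38 log units; beyond the scatter); exchanging the group on that aromatic carbon shifted the number only modestly, and no measured compound carries hydrogen there. The expected step is a 1.5-fold higher number from compound 3 to compound 4 (0.17 log units; within the scatter), a small rise or none beyond the scatter. Compound 4 is therefore estimated at 45000 nM, with a range from 20000 nM to 100000 nM.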

Compound 4, half-maximal inhibitory concentration: > 100000 nM
Compound 4: a limit, no number; the forecaster's own chance of this, stated with the estimate: 15%; at least 2.2-fold (0.34 log units) between middle value and limit.
By their numbers in this assay, from the lowest: compounds 3, 1 and 2 (each within the scatter of the next, the first and the last beyond it). At a limit, above all of these: compound 4.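

Compound 4 gives no number in this assay, only a limit: the limit of > 100000 nM in this assay, at which 1 of the 4 values shown sits. With hydrogen on that aromatic carbon, the read-out shows an at least 3.2-fold higher number from compound 3 to compound 4 (0.51 log units; beyond the scatter) and an at least 2.3-fold higher number from compound 1 to compound 4 (0.36 log units; beyond the scatter), so having cyclopropyl or 3-hydroxyphenyl there matters more than which of the two it is. The 2-hydroxyethyl comparison stays unresolved: an at least 1.3-fold higher number from compound 2 to compound 4 (0.13 log units; that floor lies within the scatter).

As far as these compounds go, how far the true value of compound 4 lies past its limit remains open. So does the effect of other groups on this carbon, such as a methyl, an amine or a longer alkyl chain.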